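This account rests on a few compounds, and the source may have more. Where it says the series, first, only, none or still open, it means among the compounds named here.

In a physicochemical assay for lipophilicity, using the shake flask method, in phosphate buffer, measured as octanol-water partition, with a stated time of 30 min, at pH 7.4 (a lower number here means a more polar compound, a higher number a more lipophilic compound), compound 1 `Cn1cc(-c2cnc(NCc3c(F)ccc4c3CCO4)c3cn[nH]c(=O)c23)cn1` gives 2.7. Among the measured compounds shown here, compound 3 `O=C1c2ccccc2CN1c1cnc(NCc2c(F)ccc3c2CCO3)n2cnnc12` gives 2.7, level with compound 1 within the usual scatter of repeated measurements, and these two share the highest of the three numbers so far. Compound 2 `Cc1ncccc1-c1cnc(NCc2c(F)ccc3c2CCO3)c2nn(CC#N)c(=O)n12` gives 2.2, and that gap to compound 1 lies beyond the scatter.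

Compound 4 `Cn1nccc1-c1cnc(NCc2c(F)ccc3c2CCO3)c2cn[nH]c(=O)c12` has not yet been measured. It holds the same atoms as compound 1, joined differently: 1-methyl-1H-pyrazol-5-yl in place of 1-methyl-1H-pyrazol-4-yl on an aromatic carbon. Here 1-methyl-1H-pyrazol-5-yl takes the place of 1-methyl-1H-pyrazol-4-yl on an aromatic carbon, and the rest of the molecule stays the same. For the measured compounds named here, the two groups match in every count, but no pair of measured compounds shows this kind of swap, so the data offer no direct precedent. The expectation therefore starts from compound 1 at 2.7, with no change beyond the scatter in this assay. The estimated step is a number 0.10 log units lower from compound 1 to compound 4 (within the scatter), a small one that is expected to stay within the scatter. For compound 4 the estimated value is 2.6, with an expected range from 2.2 to 3.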

Compound 4, distribution coefficient: 2.6
Beside the measured number, compound 4's estimate shows no gap at the digits printed; low and high end bracket the measured number.
By their numbers in this assay, from the lowest: compound 2; then compounds 4, 1 and 3 (each within the scatter of the next).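

Among the compounds shown here, compound 1 and compound 4 are the first pair here that differ in only one place, so they give the first direct reading of a change on this aromatic carbon, para to a large group. In this assay, putting 1-methyl-1H-pyrazol-5-yl in place of 1-methyl-1H-pyrazol-4-yl gives a number 0.10 log units lower from compound 1 to compound 4 (within the scatter) and so, for this pair, changing how the same ring is joined leaves the number level with that of compound 1. No separate measurement offers an explanation for this result.

This single pair cannot show whether the same swap would behave alike on another core. It also leaves open how this assay would respond if a quite different group, such as an amine or a carboxylic acid, stood on this same carbon.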